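A nitrile on the phenoxy ring of compound 2

A few compounds are considered here, and "the series" means these few. Any claim that something is new, unique, unknown or untested is made for them only; others in the source may bear on it.

Compound 2 `Cc1c(COc2ccccc2)oc2cccc(OCCCNCc3cccnc3)c12` gives 1.9 h in an in vivo ADME assay on the whole organism for pharmacokinetics, with Rattus norvegicus as the target (a higher number here means that the compound lasts longer, a lower number that the compound disappears faster), the middle of the three numbers measured, separated from compound 3 by a step within the scatter and from compound 1 by one beyond it. Compound 1 `Cc1c(C(=O)Nc2ccccc2)oc2cccc(OCCCNCc3cccnc3)c12` gives 0.9 h, and compound 3 `Cc1c(COc2ccc(Br)cc2F)oc2cccc(OCCCNCc3cccnc3)c12` gives 3.6 h. The measured steps were a 2.1-fold higher number from compound 1 to compound 2 (0.32 log units; beyond the scatter), a 4.0-fold higher number from compound 1 to compound 3 (0.60 log units; beyond the scatter) and a 1.9-fold higher number from compound 2 to compound 3 (0.28 log units; within the scatter). Compound 4 `Cc1c(COc2ccc(C#N)cc2)oc2cccc(OCCCNCc3cccnc3)c12` differs from compound 2 by cyano in place of hydrogen on an aromatic carbon, taking phenoxymethyl to (4-cyanophenoxy)methyl. For the measured compounds named here, the closest precedent is a 1.9-fold higher number from compound 2 to compound 3 (0.28 log units; within the scatter), also a substitution on that phenyl, and it stayed within the scatter. Compound 4 is therefore expected to show no step beyond the scatter, a 1.1-fold higher number from compound 2 to compound 4 (0.02 log units; within the scatter). For compound 4 the half-life is estimated at 2 h, with a range from 1 h to 4 h.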

Compound 4, half-life: 1.2 h
For compound 4 the middle estimate is 1.7-fold (0.22 log units) above the measured one; low and high end bracket the measured number.
By their numbers in this assay, from the lowest: compounds 1, 4, 2 and 3 (each within the scatter of the next, the first and the last beyond it).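

In this assay, cyano on the phenoxy ring gives a 1.6-fold lower number from compound 2 to compound 4 (0.20 log units; within the scatter), so a second substitution on this ring also stays close to the unsubstituted phenyl. The two substituted rings nevertheless separate, with a 3.0-fold lower number from compound 3 to compound 4 (0.48 log units; beyond the scatter), which shows that the substituents chosen at this ring can matter even though neither step from compound 2 leaves the scatter. Unlike compound 2 and compound 3, compound 4 is not clearly separated from the phenylcarbamoyl compound, with a 1.3-fold higher number from compound 1 to compound 4 (0.12 log units; within the scatter).

Nothing available explains these differences. Going by these compounds, it remains open whether the bromine or the fluorine accounts for the step between compound 3 and compound 4, and how a methoxy group or an amine at the position of the cyano would behave.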